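Halogen swap on the benzamide ring: tolerability in THP-1 cells

This account rests on a few compounds, and the source may have more. Where it says the series, first, only, none or still open, it means among the compounds named here.

Measured so far in a toxicity assay on THP-1 cells (Homo sapiens) for inhibition; a lower number here means that less compound is tolerated, a higher number that more compound is tolerated:
compound 1 `Cn1c(-c2ccccc2)cnc1NC(=O)c1ccccc1Cl`: compound 1 gives the limit > 50000 nM.
compound 2 `Cn1c(-c2ccc(Br)cc2)cnc1NC(=O)c1ccc(F)cc1`: compound 2 gives 46000 nM.
compound 3 `Cn1c(-c2ccccc2)cnc1NC(=O)c1ccc(Cl)cc1`: compound 3 gives the limit > 100000 nM.

Among the compounds with values here, compound 3 stands at a limit of this assay, as does compound 1, so the step that the two limits leave unreadable from compound 1 to compound 3 cannot be read; the only full number in the set is that of compound 2. Compound 4 `Cn1c(-c2ccccc2)cnc1NC(=O)c1ccc(F)cc1` differs from compound 3 by fluoro in place of chloro on an aromatic carbon. Within the data shown here, no measured step tests this change, and compound 2 carries the same fluoro group at a value near the limits. The step of an at least 1.2-fold lower number from compound 3 to compound 4 (0.09 log units; that floor lies within the scatter) is therefore expected to lie within the scatter. Compound 4 is estimated at 80000 nM, between 35000 nM and 200000 nM.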

Compound 4, half-maximal cytotoxic concentration: > 100000 nM
Compound 4 was reported as a limit (the forecaster's own chance of this, stated with the estimate: 60%); middle value at least 1.2-fold (0.09 log units) from the limit.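

In this assay compound 4 sits at a limit, as compound 3 does, so the steps that join limits cannot be read and the fluoro for chloro change shows no size: the limit of > 100000 nM in this assay, at which 2 of the 4 values shown sit.

Hydrogen in place of bromo gives the first readable step in the set, an at least 2.1-fold higher number from compound 2 to compound 4 (0.33 log units; beyond the scatter), so with the 4-fluorophenyl amide held fixed, the bromo position does shift the read-out.

Any difference between fluoro and chloro remains open while both compounds stay at the limit. Also open, as far as these compounds go, is how an amine or a carboxylic acid on that aromatic carbon would read in this assay.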